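A Methyl Group Added to Compound 1

The source may hold more compounds than are shown below. What is called first, only, known or untested is meant among the compounds shown, and "the series" means these compounds.

Three close analogues frame this step in a functional assay on MCF7 cells (Homo sapiens) for cytotoxicity, read by MTT assay, with a stated time of 96 h; on this read-out higher numbers stand for weaker inhibition and lower numbers for stronger inhibition. Compound 1 (`COc1cc(C(=O)c2cn(-c3ccccc3)cc2-c2ccccc2Cl)cc(OC)c1OC`) gives 76 nM and holds the lowest number of the three, while compound 2 (`COc1cc(C(=O)c2cn(-c3ccccc3)cc2-c2ccc(Cl)cc2)cc(OC)c1OC`) gives 290 nM and compound 3 (`COc1cc(C(=O)c2cn(-c3ccccc3)cc2-c2cccc(Br)c2)cc(OC)c1OC`) gives 950 nM on the same read-out. Compound 4 (`COc1cc(C(=O)c2cn(-c3cccc(C)c3)cc2-c2ccccc2Cl)cc(OC)c1OC`) differs from compound 1 by methyl in place of hydrogen on an aromatic carbon as methyl in place of hydrogen on an aromatic carbon, meta to a large group, turning phenyl into 3-methylphenyl.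

Among the measured compounds shown here, no measured step tests this change, since all of them alter the halogenated phenyl group instead. For the measured compounds named here, they show only that the number of compound 1 rose with each change made to it (a 3.8-fold higher number from compound 1 to compound 2 (0.58 log units; beyond the scatter); a 13-fold higher number from compound 1 to compound 3 (1.10 log units; beyond the scatter)), the first modest and the second large. The data therefore support only a tentative expectation of a small upward move. The expected step is small (a 1.7-fold higher number from compound 1 to compound 4 (0.23 log units; within the scatter)). Compound 4 is estimated at 130 nM with an expected range from 40 nM to 420 nM in this measurement.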

Compound 4, half-maximal inhibitory concentration: 420 nM
Compound 4: middle estimate off by 3.2-fold (0.51 log units), on the low side, and the stated range covers the measured number.
By their numbers in this assay, from the lowest: compound 1; then compounds 2 and 4 (each within the scatter of the next); then compound 3.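

Among the compounds shown here, the phenyl group that all the earlier steps left untouched turns out not to be a silent part of the molecule. In this assay, turning phenyl into 3-methylphenyl, a change of a single carbon, gives a 5.5-fold higher number from compound 1 to compound 4 (0.74 log units; beyond the scatter), so the number moves towards weaker inhibition and this site responds to even the smallest carbon substituent. Nothing at hand accounts for the size of this rise.

For the compounds shown here, the single pair cannot tell whether the rise is particular to methyl or whether a methoxy group, a chlorine atom or an amine in the same place would move the number as far. It also leaves open whether the same methyl would have a comparable effect when the 2-chlorophenyl group of compound 1 is replaced by the 4-chlorophenyl group of compound 2.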